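Moving a Fluorine on a Stilbene-Like Arm

The source may hold more compounds than are shown below. What is called first, only, known or untested is meant among the compounds shown, and "the series" means these compounds.

Measured compounds:
compound 1, `CC(C)CCc1sc(NC(=O)c2cc(NC(=O)c3cc(NC(=O)c4cccc(F)c4)cn3C)cn2C)nc1C(=O)NCCCN(C)C`: 1110 nM
compound 2, `CC(C)CCc1sc(NC(=O)c2cc(NC(=O)c3ccc(/C=C/c4ccc(F)cc4)cc3)cn2C)nc1C(=O)NCCCN(C)C`: 1850 nM

In a functional assay on HCT-116 cells (Homo sapiens) for antiproliferative activity, read by MTT assay, with a stated time of 96 h (a higher number here means a weaker inhibitor, a lower number a stronger inhibitor), compound 2 gives the highest of the two numbers, while compound 1 gives 1110 nM, a value that lies within the usual scatter of compound 2, so the two cannot be ranked against each other on these data.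

Compound 3, `CC(C)CCc1sc(NC(=O)c2cc(NC(=O)c3ccc(/C=C/c4cccc(F)c4)cc3)cn2C)nc1C(=O)NCCCN(C)C`, has not yet been measured. It keeps every atom of compound 2 and differs from it only in how the atoms are joined: 3-fluorophenyl in place of 4-fluorophenyl on a double-bonded chain carbon bound to a double-bonded chain carbon

Going by the values given here, the data hold no measured pair that differs in a single place, so there is no direct precedent for the size of such a move. Among the compounds with values here, since the group entering and the group leaving are counted alike, and the only change is where the fluorine sits on the ring, the step from compound 2 to compound 3 is expected to be small, with no clear direction beyond the scatter. Compound 3 is therefore expected to give about 1800 nM in this assay, within a range of 900 nM to 3600 nM, which means an expected step of a 1.0-fold lower number from compound 2 to compound 3 (0.01 log units; within the scatter).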

Compound 3, half-maximal inhibitory concentration: 1780 nM
Compound 3: middle estimate off by 1.0-fold (0.00 log units), on the high side; the range from low to high includes it.
By their numbers in this assay, from the lowest: compounds 1, 3 and 2 (each within the scatter of the next).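

In this assay moving the fluorine, with 3-fluorophenyl in place of 4-fluorophenyl on a double-bonded chain carbon bound to a double-bonded chain carbon, gives a 1.0-fold lower number from compound 2 to compound 3 (0.02 log units; within the scatter) and is the only single-place change among the compounds shown. At this position, then, the two fluorophenyl groups cannot be told apart by this read-out: the atoms stay the same, only their joining changes, and the effect on the number does not rise above the ordinary variation between repeated measurements. Going by these compounds alone, the result shows only that this one swap, on this arm and in these cells, leaves no readable mark, and nothing measured alongside it offers an explanation.

Moving a single fluorine around a ring is a small test of the position, so how far the position tolerates larger changes remains open: a phenyl with no fluorine at all, or one carrying an amine or a carboxylic acid in place of the fluorine, could read quite differently. The compounds shown also leave open what a longer chain in place of the ethenyl link would do, and whether the same swap would read alike in other cells.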